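The source may report more compounds than this note shows. Statements on the series, on what has been measured and on what is new or still open speak of the compounds shown alone.

Measured in a functional assay on L02 cells (Homo sapiens) for inhibition, read by Griess assay, with stated times of 1 h and 24 h; a lower number here means a stronger inhibitor, a higher number a weaker inhibitor:
Compound 1 `CC(C)Nc1nc(/C=C/c2ccccc2)nc2ccsc12` gives > 1000000 nM, which is a limit of the assay.
Compound 2 `CC(C)CNc1nc(/C=C/c2ccccc2)nc2ccsc12` gives > 1000000 nM, also a limit.
Compound 3 `COc1cc(/C=C/c2nc(Nc3ccc(C(C)C)cc3)c3sccc3n2)cc(OC)c1OC` gives 370000 nM.

Among the measured compounds shown here, compound 3 holds the only number in this assay; the other two values sit at the limit described by the limit of > 1000000 nM in this assay, at which 2 of the 3 values shown sit. The step that the two limits leave unreadable from compound 1 to compound 2 therefore cannot be read. Compound 4 `COc1cc(/C=C/c2nc(NCc3ccc(Cl)cc3)c3sccc3n2)cc(OC)c1OC` differs from compound 3 by 4-chlorobenzyl in place of 4-isopropylphenyl on a nitrogen on an aromatic ring. For the measured compounds named here, no measured step covers an exchange of this kind, and the lone unreadable step gives no size to borrow. The expectation for compound 4 is thus anchored on compound 3 alone, with a wide range and a fair chance that this assay again returns only a limit. Compound 4 is estimated at 500000 nM, between 120000 nM and 2000000 nM. The step of a 1.4-fold higher number from compound 3 to compound 4 (0.13 log units; within the scatter) so expected lies within the usual scatter.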

Compound 4, half-maximal inhibitory concentration: > 1000000 nM
Compound 4 ended at the assay's limit; the forecaster's own chance of this, stated with the estimate: 35%; middle value at least 2.0-fold (0.30 log units) from the limit.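

At the place on a nitrogen on an aromatic ring, the series now has a readable step in this assay: 4-chlorobenzyl in place of 4-isopropylphenyl gives an at least 2.7-fold higher number from compound 3 to compound 4 (0.43 log units; beyond the scatter) and so a weaker inhibitor. Inhibition in this small set therefore responds to the group on this nitrogen, although the exchange alters both the ring substituent and its link to the nitrogen. From the compounds shown here alone, whether 4-chlorophenyl or plain benzyl would separate those two changes stays open. The full size of the step also stays open, with only one bound on it: the limit of > 1000000 nM in this assay, at which 3 of the 4 values shown sit.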